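Fluoro for Chloro on the Benzylsulfanyl Arm

This account rests on a few compounds, and the source may have more. Where it says the series, first, only, none or still open, it means among the compounds named here.

In a functional assay on the whole organism (artery, strain albino) with Rattus norvegicus as the target, with a stated time of 120 min, at a dose of 10 mg/kg by the oral route (a higher number here means more inhibition at the dose given (going by the name of the read-out), a lower number less inhibition), the measured compounds stand as follows:
compound 1 `CC1=C(C(=O)Nc2ccc(Br)cc2)C(c2ccc(Cl)cc2Cl)N=C(SCc2ccc(Cl)cc2)N1` gives 17.5%
compound 2 `CC1=C(C(=O)Nc2ccc(Br)cc2)C(c2ccc(Cl)cc2Cl)N=C(SCc2ccc(F)cc2)N1` gives 22.7%
compound 3 `CC1=C(C(=O)Nc2ccc([N+](=O)[O-])cc2)C(c2ccc(Br)cc2)N=C(SCc2ccc(Cl)cc2)N1` gives 13.9%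

Compound 1 and compound 3 differ in more than one place; the difference between the two cores is not broken down here. Compound 2 differs from compound 1 by fluoro in place of chloro on an aromatic carbon, and in this assay this change made a number 5.2 percentage points higher from compound 1 to compound 2 (within the scatter). Compound 4 `CC1=C(C(=O)Nc2ccc([N+](=O)[O-])cc2)C(c2ccc(Br)cc2)N=C(SCc2ccc(F)cc2)N1` differs from compound 3 by fluoro in place of chloro on an aromatic carbon, the same change on the same kind of place. Among the measured compounds shown here, the step expected from compound 3 to compound 4 is estimated as a number 4.1 percentage points higher from compound 3 to compound 4 (within the scatter), beside the earlier step, because the only precedent is a number 5.2 percentage points higher from compound 1 to compound 2 (within the scatter) and it lies within the scatter. Compound 4 is therefore expected to give about 18%, between 8% and 28%.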

Compound 4, a percentage reported as inhibition, in the whole organism at one dose (the size of the read-out at that dose, not a potency): 12.9%
Estimate against measurement, compound 4: 5.1 percentage points above, within the range that was stated.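

In this assay, replacing 4-chlorobenzyl with 4-fluorobenzyl on the core of compound 3 gives a step of a number 1 percentage points lower from compound 3 to compound 4 (within the scatter). Set beside the earlier step, the same change does not separate the two cores: the same change on two cores in this assay, a number 5.2 percentage points higher (within the scatter) from compound 1 to compound 2 and a number 1 percentage points lower (within the scatter) from compound 3 to compound 4, 6.2 percentage points apart, within the scatter of two such steps. This shows that the change gives no step beyond the scatter on either core, but it does not show that the change carries over with a shared effect, nor that its effect depends on the core.

The compounds shown leave open what an amine or a carboxylic acid would give on that aromatic carbon in place of the halogen. They also leave open what a longer chain would give in place of the benzyl group on sulfur.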